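This account rests on a few compounds, and the source may have more. Where it says the series, first, only, none or still open, it means among the compounds named here.

Measured compounds:
compound 1 `Cn1cc(S(=O)(=O)Nc2ccc(Cc3nc4c([nH]3)c(=O)n(Cc3ccccc3F)c(=O)n4CC3CC3)cc2)cn1` with 390 nM
compound 2 `CCCCn1c(=O)n(Cc2ccccc2F)c(=O)c2[nH]c(Cc3ccc(N)cc3)nc21` with 2560 nM

In an assay on isolated protein for inhibition of phosphoenolpyruvate carboxykinase, cytosolic [GTP] (Homo sapiens) (a higher number here means a weaker inhibitor, a lower number a stronger inhibitor), compound 1 gives 390 nM, the lowest of the two numbers; compound 2 gives 2560 nM, a higher number that lies beyond the scatter. Compound 3 `CN(C)CC(=O)Nc1ccc(Cc2nc3c([nH]2)c(=O)n(Cc2ccccc2F)c(=O)n3CC2CC2)cc1` has not been measured. It differs from compound 1 in one place: ((dimethylamino)methyl)carbonyl in place of (1-methyl-1H-pyrazol-4-yl)sulfonyl on a nitrogen on an aromatic ring. Within the data shown here, no step between measured compounds covers this change. A step from compound 1 to compound 3 of about a 2.3-fold higher number from compound 1 to compound 3 (0.36 log units; beyond the scatter) toward a higher number is expected, of moderate size. Compound 3 is therefore estimated at 900 nM, within 250 nM to 3000 nM.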

Compound 3, half-maximal inhibitory concentration: 2070 nM
Estimate against measurement, compound 3: 2.3-fold (0.36 log units) below; low and high end bracket the measured number.
By their numbers in this assay, from the lowest: compound 1; then compounds 3 and 2 (each within the scatter of the next).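

The nitrogen on the aromatic ring proves to be a position that responds to change: in this assay putting ((dimethylamino)methyl)carbonyl in place of (1-methyl-1H-pyrazol-4-yl)sulfonyl gives a 5.3-fold higher number from compound 1 to compound 3 (0.72 log units; beyond the scatter) with the rest of the molecule unchanged. Of these two groups, the sulfonyl one with its five-membered aromatic ring gives the stronger inhibitor. Nothing measured here accounts for the step. On these data alone, whether the sulfonyl or the ring carries the difference stays open. Methylsulfonyl or 1-methyl-1H-pyrazole-4-carbonyl on this nitrogen would separate the two.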